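The compounds below may be only part of what the source reports. "The series", "measured", "known", "first", "only" and "open" are said of these compounds alone.

Measured compounds:
- compound 2, `COC1Cc2cc(-c3ccc([N+](=O)[O-])cc3)sc2C2(CCN(Cc3ccccc3)CC2)O1`: 16 nM in an assay on membranes from brain for displacement of a labelled ligand from Sigma non-opioid intracellular receptor 1 (Cavia porcellus), read by scintillation counting, with a stated time of 120 min; a lower number here means a stronger inhibitor, a higher number a weaker inhibitor
- compound 1, `COC1Cc2sc(-c3ccc(-c4ccccc4)cc3)cc2C2(CCN(Cc3ccccc3)CC2)O1`: 220 nM in this assay

Of the two compounds measured in this assay, compound 2 stands with the lower number, and its gap to compound 1 lies beyond the scatter of repeated measurements, so compound 2 is the stronger inhibitor of the pair. Compound 3, `COC1Cc2cc(-c3cccc4ccccc34)sc2C2(CCN(Cc3ccccc3)CC2)O1`, has not yet been measured in this assay. It differs from compound 2 in one place: naphthalen-1-yl in place of 4-nitrophenyl on an aromatic carbon. Among the compounds with values here, no pair of measured compounds differing in one place is available, so the size of this step cannot be read from the data and can only be expected. Since an aromatic group on the same carbon of the shared core already gives a low number in compound 2, and the change keeps an aromatic group in that place, compound 3 is expected to stay near compound 2, with at most a small step toward a higher number, likely within the scatter. Compound 3 is estimated at 30 nM in this assay, within a range from 8 nM to 120 nM, which means an expected step of a 1.9-fold higher number from compound 2 to compound 3 (0.27 log units; within the scatter).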

Compound 3, inhibition constant: 12 nM
Compound 3: the middle estimate sits 2.5-fold (0.40 log units) above what was measured, within the range that was stated.
By their numbers in this assay, from the lowest: compounds 3 and 2 (each within the scatter of the next); then compound 1.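

In this assay, putting naphthalen-1-yl in place of 4-nitrophenyl on this aromatic carbon, next to the ring sulfur, gives a 1.3-fold lower number from compound 2 to compound 3 (0.12 log units; within the scatter), so the two compounds cannot be told apart in this assay. Within the data shown here, this is the first comparison here between compounds that differ in only one place, and it shows that two quite different groups can sit on this carbon with no step beyond the scatter: the group that leaves holds nitrogen and oxygen, has a single aromatic ring and carries hydrogen-bond acceptors, while the group that enters is carbon only, has two fused aromatic rings and carries no such acceptors. No measurement is at hand that would explain why the number stays within the scatter across this change, so the result stands as an observation only.

Still open, as far as these compounds go, is whether an aromatic ring is needed on this carbon at all, for example whether a plain hydrogen, a methyl group, a longer alkyl chain or an amine would give a similar number. Also open, from the compounds shown here alone, is how an aromatic ring containing nitrogen, such as pyridine, would behave in the same place.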